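The source may hold more compounds than are shown below. What is called first, only, known or untested is meant among the compounds shown, and "the series" means these compounds.

Measured so far:
compound 1 `Cn1cc(-c2ccccc2NCC2=NCCN2)cn1` gives 39%
compound 2 `c1ccc(-c2cn[nH]c2)c(NCC2=NCCN2)c1` gives 112%
compound 3 `Cn1ccc(-c2ccccc2NCC2=NCCN2)n1` gives 116%

In a functional assay with Alpha-1A adrenergic receptor (Homo sapiens) as the target, read by calcium flux (on this read-out higher numbers stand for larger maximal responses and lower numbers for smaller maximal responses), compound 3 stands highest of the three numbers, yet compound 2 lies only a number 4 percentage points higher from compound 2 to compound 3 (within the scatter) away, a gap within the scatter, so the two cannot be told apart. Compound 1 sits far lower, a number 77 percentage points higher from compound 1 to compound 3 (beyond the scatter) beyond the scatter.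

Compound 4 `c1ccc(-c2nc[nH]n2)c(NCC2=NCCN2)c1` has not yet been measured. It differs from compound 3 by 1H-1,2,4-triazol-3-yl in place of 1-methyl-1H-pyrazol-3-yl on an aromatic carbon. Going by the values given here, two measured steps bear on this. The exchange of one five-membered ring for another, from compound 2 to compound 3, moved the maximal response by a number 4 percentage points higher from compound 2 to compound 3 (within the scatter), which is within the scatter. The loss of the methyl on the ring nitrogen, from compound 1 to compound 2, raised the response by a number 73 percentage points higher from compound 1 to compound 2 (beyond the scatter), a large step, and compound 4 likewise carries a hydrogen rather than a methyl on its ring nitrogen. Since compound 3 already gives a high maximal response, no step beyond the scatter is expected in this assay, so the step from compound 3 to compound 4 is estimated at a number 8 percentage points lower from compound 3 to compound 4 (within the scatter). Compound 4 is therefore expected to give about 108%, within a range from 75% to 135%.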

Compound 4, largest response reached (reported as maximal response), in percent of the reference or control that the assay uses: 135%
The estimate for compound 4 lay 27 percentage points below the measured number; low and high end bracket the measured number.
By their numbers in this assay, from the lowest: compound 1; then compounds 2 and 3 (each within the scatter of the next); then compound 4.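

In this assay, the aromatic carbon ortho to a group of 7 heavy atoms proves sensitive even among rings that already give a high response: 1H-1,2,4-triazol-3-yl in place of 1-methyl-1H-pyrazol-3-yl gives a modest rise (a number 19 percentage points higher from compound 3 to compound 4 (beyond the scatter)), and in place of 1H-pyrazol-4-yl it gives a similar one (a number 23 percentage points higher from compound 2 to compound 4 (beyond the scatter)), whereas the exchange of those two pyrazole groups stayed within the scatter. The far larger rise from the low end of the set (a number 96 percentage points higher from compound 1 to compound 4 (beyond the scatter)) shows that the choice of five-membered ring at this one position spans the whole range seen so far. Going from compound 3 to compound 4 removes the methyl, adds a third ring nitrogen and adds a hydrogen-bond donor all at once, so these data cannot assign the rise to any one of those changes, and no supporting measurement offers an explanation for it.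

From the compounds shown here alone, it remains open whether 1-methyl-1H-1,2,4-triazol-3-yl would keep the response of compound 4 or fall as compound 1 does. Going by these compounds, how a group without a ring, such as a primary amine, a carboxylic acid or a longer alkyl chain, would behave at this position also remains unknown.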